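The compounds below may be only part of what the source reports. "The series", "measured", "known", "first", "only" and "open" are said of these compounds alone.

Working notes on the series

Compound 1 `COC[C@@H](C(C)C)C(c1ccc(O)c(OC)c1)c1ccc(O)c(OC)c1` gives 54000 nM in a functional assay on HL-60 cells (Homo sapiens) for cytotoxicity, read by WST assay, with a stated time of 48 h; on this read-out lower numbers stand for stronger inhibition and higher numbers for weaker inhibition. Among the two numbers gathered so far this is the lowest, with compound 2 `COC[C@H](C)[C@@H](C)C(c1ccc(O)c(OC)c1)c1ccc(O)c(OC)c1` nearest at 68000 nM; the one measured step, a 1.3-fold higher number from compound 1 to compound 2 (0.10 log units; within the scatter), stays inside the scatter, so no order between these two should be read.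

Compound 3 `COc1cc(C(c2ccc(O)c(OC)c2)[C@H](CO)C(C)C)ccc1O` is not yet measured. It differs from compound 1 in one place: 1-(hydroxymethyl)-2-methylpropyl in place of 1-(methoxymethyl)-2-methylpropyl on a saturated chain carbon bound to two aromatic carbons. Among the measured compounds shown here, the only step recorded so far rearranges the side chain on the same saturated chain carbon and gives no sign of a change beyond scatter; no measured pair trades a methoxymethyl for a hydroxymethyl group, so nothing speaks directly to the change made here. The working expectation is therefore a step of no more than the scatter in this assay, in no preferred direction, set here as a 1.1-fold higher number from compound 1 to compound 3 (0.05 log units; within the scatter). On that basis compound 3 is expected to give about 60000 nM in this assay, within a range from 25000 nM to 150000 nM.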

Compound 3, half-maximal inhibitory concentration: > 100000 nM
Compound 3: no number, only a limit; the forecaster's own chance of this, stated with the estimate: 20%; middle value at least 1.6-fold (0.22 log units) from the limit.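

The value of compound 3 in this assay is a limit of the assay and not a number: the limit of > 100000 nM in this assay, at which 1 of the 3 values shown sits.

Against the two measured compounds it yields only floors (an at least 1.8-fold higher number from compound 1 to compound 3 (0.26 log units; that floor lies within the scatter)) and (an at least 1.4-fold higher number from compound 2 to compound 3 (0.16 log units; that floor lies within the scatter)), so 1-(hydroxymethyl)-2-methylpropyl on this saturated chain carbon is the first side chain in the series to give no number in this read-out, whereas the rearranged 2-(methoxymethyl)-1-methylpropyl chain of compound 2 still gave one. Among the compounds shown here, both floors lie within the scatter, so the limit fixes no size for the step: the change from methoxymethyl to hydroxymethyl may be small or much larger, and the data show only its direction as far as a floor can show one.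

Where compound 3 truly stands remains open, and with it whether the loss of the methyl on that oxygen matters at all beyond the scatter. Also open, on these data alone, is how this position would respond to an aminomethyl group, a carboxylic acid or a longer alkoxymethyl chain in place of the hydroxymethyl end, and whether 2-(hydroxymethyl)-1-methylpropyl would behave as 1-(hydroxymethyl)-2-methylpropyl does here.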